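The compounds below may be only part of what the source reports. "The series", "measured", "known", "first", "only" and "open" are said of these compounds alone.

In an ADME assay on Vero cells (Chlorocebus sabaeus) for cytotoxicity, read by crystal violet staining (a higher number here means that more compound is tolerated, a lower number that less compound is tolerated), three compounds have been measured so far. Compound 1 `Clc1cccc(/N=N/N2CCCC2)c1` reads >= 100000 nM, which is a limit of the assay and not a number. Compound 3 `c1ccc(/N=N/N2CCN(c3ccccc3)CC2)cc1` reads >= 100000 nM, which is likewise a limit. Going by the values given here, compound 2 `Fc1ccc(F)c(/N=N/c2ccc(NC[C@@H]3CCCN4CCCC[C@H]34)c3c2CCCC3)c1` gives 80000 nM, the only true number among the three.

Compound 4 `c1ccc(/N=N/c2ccc(NC[C@@H]3CCCN4CCCC[C@H]34)c3c2CCCC3)cc1` has not yet been measured in this assay. It differs from compound 2 in a single place, with phenyl in place of 2,5-difluorophenyl on a double-bonded nitrogen. Among the compounds with values here, no step between measured compounds is available to size this change, so no shift beyond the usual scatter is expected in this assay, in either direction. Within the data shown here, that expectation rests on the one number available, from compound 2 at 80000 nM. The step expected is no change at the digits printed from compound 2 to compound 4 (within the scatter). For compound 4 the estimated half-maximal cytotoxic concentration is 80000 nM, with an expected range from 40000 nM to 100000 nM.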

Compound 4, half-maximal cytotoxic concentration: 80000 nM
For compound 4 middle estimate and measured number coincide at the digits printed; measured number inside the range.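

In this assay, putting phenyl in place of 2,5-difluorophenyl on a double-bonded nitrogen gives no change at the digits printed from compound 2 to compound 4 (within the scatter). Going by these compounds alone, this is the first step to size any change at this place, and it shows that the two fluorine atoms counted in the leaving group can go without a shift that this read-out can tell. The step is read near the end of the measurable scale, so it has little room to show a rise: the limit of >= 100000 nM in this assay, at which 2 of the 4 values shown sit.

On these data alone, it stays open whether a phenyl carrying a carboxylic acid or an amine at this place, or a pyridine in place of the phenyl, would read any differently. Also open, as far as these compounds go, is whether a change elsewhere in the shared core of compound 2 and compound 4 would move the value.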